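From Phenyl to Furan-2-yl on Compound 3

A few compounds are considered here, and "the series" means these few. Any claim that something is new, unique, unknown or untested is made for them only; others in the source may bear on it.

In a functional assay on MDA-MB-231 cells (Homo sapiens) for inhibition, read by CCK-8 assay, with a stated time of 48 h (a lower number here means a stronger inhibitor of growth, a higher number a weaker inhibitor of growth), compound 1 (`Cc1ccccc1Nc1nc(Nc2ccccn2)ncc1Cl`) gives 11200 nM and compound 2 (`Cc1ccccc1Nc1nc(Nc2ccc(N3CCCN(C)CC3)cc2)ncc1Cl`) gives 6390 nM. Compound 3 (`CN1CCN(c2ccc(Nc3ncc(Cl)c(NCc4ccccc4)n3)nc2)CC1`) gives 24800 nM as the highest of the three numbers, which makes it the weakest inhibitor of growth so far. Compound 4 (`CN1CCN(c2ccc(Nc3ncc(Cl)c(NCc4ccco4)n3)nc2)CC1`) has furan-2-yl in place of phenyl on a saturated chain carbon bound to a nitrogen on an aromatic ring. Going by the values given here, no measured pair shows this exchange, and the rest of the structure stays the same, so no step beyond the scatter is expected in this assay. The estimated change is a 1.2-fold lower number from compound 3 to compound 4 (0.09 log units; within the scatter) in this reading. For compound 4 the expected value is 20000 nM (estimated range 9000 nM to 45000 nM).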

Compound 4, concentration for 50% growth inhibition: 11000 nM
Beside the measured number, compound 4's estimate is 1.8-fold (0.26 log units) above it, and the stated range covers the measured number.
By their numbers in this assay, from the lowest: compounds 2, 4 and 1 (each within the scatter of the next); then compound 3.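

The group on the saturated chain carbon bound to a nitrogen on an aromatic ring affects the read-out in this assay: furan-2-yl in place of phenyl gives a 2.3-fold lower number from compound 3 to compound 4 (0.35 log units; beyond the scatter). Going by these compounds alone, this is the first measured pair that differs in one place, and it shows that this position responds to a change of ring, though modestly. No measurement at hand explains the step. As far as these compounds go, it remains open whether the ring oxygen or the smaller ring size matters, and thiophen-2-yl or pyridin-2-yl at this place would bear on that question.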